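Stereoisomer step within a cytotoxicity series at the limit

The source may hold more compounds than are shown below. What is called first, only, known or untested is meant among the compounds shown, and "the series" means these compounds.

Three compounds of one shared core are followed. Compound 1 `CC1=CC[C@@]2(O)[C@H](C)CC[C@@H](C(C)C)[C@@H]2C1=O` and compound 2 `CC1=CC[C@]2(O)[C@@H]([C@@H]1O)[C@H](C(C)C)CC[C@H]2C` have been measured; compound 3 `CC1=CC[C@]2(O)[C@@H]([C@H]1O)[C@H](C(C)C)CC[C@H]2C` has not. In a functional assay on BGC-823 cells (Homo sapiens) for cytotoxicity, read by MTT assay (on this read-out higher numbers stand for weaker inhibition and lower numbers for stronger inhibition), compound 1 gives only a limit, > 10 ug/mL. Compound 2 likewise gives only a limit in this assay, > 10 ug/mL. Compound 2 therefore stands nowhere distinct on the numbers shown: both measured values sit at the same limit, as the evidence summarises, (the limit of > 10 ug/mL in this assay, at which 2 of the 2 values shown sit), and no step between measured compounds can be stated.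

The change from compound 2 to compound 3 is the two compounds have the same atoms and bonds and differ only in configuration as drawn: 1 of 5 stereo elements differ; a stereocentre at a saturated ring carbon is drawn S in compound 2 and R in compound 3. Among the measured compounds shown here, no measured step of this kind exists, so nothing shows whether a change of configuration alone moves the read-out. Because both values shown sit at the limit (the limit of > 10 ug/mL in this assay, at which 2 of the 2 values shown sit), compound 3 is expected to remain there as well, with a step from compound 2 of a step that the limit leaves unreadable from compound 2 to compound 3, that is none beyond the scatter. For compound 3 the expected value in this assay is 15 ug/mL, with an estimated range from 5 ug/mL to 60 ug/mL, most likely reported again only as a limit.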

Compound 3, half-maximal inhibitory concentration: > 10 ug/mL
Compound 3 gave a limit, no number; the forecaster's own chance of this, stated with the estimate: 80%; the middle value is on the limit's open side.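

No step can be read between compound 2 and compound 3 in this assay: the limit of > 10 ug/mL in this assay, at which 3 of the 3 values shown sit.

The compounds shown leave open whether a change of configuration at this saturated ring carbon alone moves the read-out, and where any of compounds 1, 2 and 3 would fall if given a number rather than a limit.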